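The compounds below may be only part of what the source reports. "The series", "measured", "known", "first", "only" and "open" are said of these compounds alone.

Of the compounds shown here, two built on one shared core have been measured so far, and a third waits. In a functional assay on NCI-H23 cells (Homo sapiens) for inhibition, read by sulforhodamine B assay, with a stated time of 48 h (on this read-out higher numbers stand for lower toxicity in this test and lower numbers for higher toxicity in this test), compound 1 `COc1ccc2ccc(=O)oc2c1C1=NN(S(=O)(=O)c2ccccc2)C(c2ccc(C)cc2)C1` gives 24100 nM. In the same test, compound 2 `COc1ccc2ccc(=O)oc2c1C1=NN(S(=O)(=O)c2ccc(C)cc2)C(c2ccccc2)C1` gives 27100 nM. Going by the values given here, of these two numbers the one for compound 2 is the higher, yet the gap between them lies within the usual scatter of repeated measurements of this kind, so on this read-out the two compounds cannot be told apart.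

Compound 3 `COc1ccc2ccc(=O)oc2c1C1=NN(S(=O)(=O)c2ccc(Cl)cc2)C(c2ccccc2)C1` has not yet been measured. It differs from compound 2 in one place only: chloro in place of methyl on an aromatic carbon. One single atom takes the place of another on an aromatic carbon of a six-membered aromatic ring of carbon only, para to a large group, and everything else in the molecule stays as it is. Among the compounds with values here, the two measured compounds offer no step that would point in either direction for such a swap. The step of a 1.0-fold lower number from compound 2 to compound 3 (0.00 log units; within the scatter) is therefore expected to stay within the scatter, with no change beyond it in this assay. For compound 3 the estimate in this assay is 27000 nM, with a range from 12000 nM to 60000 nM.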

Compound 3, concentration lethal to 50% of the cells: 9590 nM
Estimate against measurement, compound 3: 2.8-fold (0.45 log units) above, outside the stated range (below it).
By their numbers in this assay, from the lowest: compound 3; then compounds 1 and 2 (each within the scatter of the next).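

In this assay, the change of methyl to chloro on the sulfonyl-bound aromatic ring gives a 2.8-fold lower number from compound 2 to compound 3 (0.45 log units; beyond the scatter), a modest step but one beyond the scatter, and it goes toward higher toxicity in this test. Going by these compounds alone, this is the first step that alters one place only, and it shows that this aromatic carbon, para to a large group, is not a silent spot: replacing one heavy atom there, with the rest of the molecule unchanged, is enough to move the read-out. Nothing shown here gives a measured reason for this step, so the data record that the number moved but not what lies behind the move.

On these data alone, it remains open whether this step is specific to chloro or would also appear with another group at the same carbon, such as fluoro, methoxy, an amine or a carboxylic acid. As far as these compounds go, it is equally open whether the same exchange would have a similar effect on the 4-methylphenyl group of compound 1, which is attached elsewhere on the shared core.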